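A few compounds are considered here, and "the series" means these few. Any claim that something is new, unique, unknown or untested is made for them only; others in the source may bear on it.

Measured so far:
compound 1, `Cn1cc(-c2nc3ccccc3n2C(=O)c2ccccc2)c2ccccc21`: 43700 nM
compound 2, `COc1ccc2c(c1)c(-c1nc3ccccc3n1C(=O)c1ccccc1)cn2C`: 38400 nM

Both numbers come from a functional assay on MCF7 cells (Homo sapiens) for inhibition, read by MTT assay, with a stated time of 24 h; on this read-out higher numbers stand for weaker inhibition of growth and lower numbers for stronger inhibition of growth. For the measured compounds named here, compound 2 stands at the low end of the two, but the only step measured, a 1.1-fold lower number from compound 1 to compound 2 (0.06 log units; within the scatter), is within the scatter, so on this assay compound 1 and compound 2 cannot be told apart; both sit in the weak range.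

Compound 3, `COc1ccc2c(c1)c(-c1nc3ccccc3n1C(=O)c1ccccc1Br)cn2C`, is the next compound in line. It differs from compound 2 by bromo in place of hydrogen on an aromatic carbon. Going by the values given here, the one measured step bears on a different part of the molecule and was within the scatter, so there is no measured change at the place where the bromo enters and nothing in the data that points to a direction. The change is a single heavy atom entering, and the parent numbers are both weak; the expectation is therefore no step beyond the scatter, with the range kept wide to cover the lack of a comparison at this position.

The estimated step from compound 2 to compound 3 in this assay is a 1.0-fold lower number from compound 2 to compound 3 (0.00 log units; within the scatter). Compound 3 is expected to give 38000 nM, with a range from 15000 nM to 95000 nM.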

Compound 3, concentration for 50% growth inhibition: 55800 nM
Beside the measured number, compound 3's estimate is 1.5-fold (0.17 log units) below it, and the stated range covers the measured number.
By their numbers in this assay, from the lowest: compounds 2, 1 and 3 (each within the scatter of the next).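

In this assay, phenyl to 2-bromophenyl gives a 1.5-fold higher number from compound 2 to compound 3 (0.16 log units; within the scatter), which provides a reading at the benzoyl group, a part of the molecule the step from compound 1 to compound 2 did not touch. Bromo in place of hydrogen, on an aromatic carbon ortho to a large group, therefore leaves compound 2 and compound 3 indistinguishable on this read-out, and this single heavy atom does not lift the compounds out of the weak range. No available evidence bears on this result.

Open, from the compounds shown here alone, is whether a different group at this place, such as an amine, a carboxylic acid, a chloro or a longer chain, would give a step beyond the scatter, and whether bromo elsewhere on the same six-membered ring would read differently from the 2-bromophenyl of compound 3. Also open, going by these compounds, is whether any change on the benzoyl group can move the series clear of the weak range, since this one step, lying within the scatter, sets no direction for the position.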